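Extending a Pyridine Amide on Two Related Cores

A few compounds are considered here, and "the series" means these few. Any claim that something is new, unique, unknown or untested is made for them only; others in the source may bear on it.

Measured so far in a functional assay on CHO cells for antagonist activity at growth hormone secretagogue receptor type 1 (Homo sapiens); a higher number here means a weaker inhibitor, a lower number a stronger inhibitor:
- compound 1, `COc1ccc(-n2c(CCc3ccccc3)nnc2[C@H](NC(=O)c2ccccn2)c2c[nH]c3ccccc23)c(OC)c1`, gives 65 nM
- compound 2, `CCc1ccc(-n2c(CCc3c[nH]c4ccccc34)nnc2[C@H](NC(=O)c2ccccn2)c2c[nH]c3ccccc23)cc1`, gives 129 nM
- compound 3, `COc1ccc(-n2c(CCc3ccccc3)nnc2[C@H](NC(=O)Cc2ccccn2)c2c[nH]c3ccccc23)c(OC)c1`, gives 35 nM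

Compound 1 and compound 3 share one core and differ only by the change ((pyridin-2-yl)methyl in place of pyridin-2-yl on a carbonyl carbon). That change gave a 1.9-fold lower number from compound 1 to compound 3 (0.27 log units; within the scatter), so the two compounds cannot be ranked against each other. Compound 2 is built on a different core; the difference between the two cores is not broken down here. Its value and that of compound 1 lie within the scatter of each other, while compound 3 stands beyond the scatter from compound 2.

Compound 4, `CCc1ccc(-n2c(CCc3c[nH]c4ccccc34)nnc2[C@H](NC(=O)Cc2ccccn2)c2c[nH]c3ccccc23)cc1`, is not yet measured. It relates to compound 2 exactly as compound 3 relates to compound 1: the change is (pyridin-2-yl)methyl in place of pyridin-2-yl on a carbonyl carbon, at the same place. Because the same change gave only a 1.9-fold lower number from compound 1 to compound 3 (0.27 log units; within the scatter), a similarly small shift is expected here, namely a 1.8-fold lower number from compound 2 to compound 4 (0.27 log units; within the scatter) in this assay. Compound 4 is therefore expected to give about 70 nM, with a likely range from 30 nM to 180 nM.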

Compound 4, antagonist equilibrium constant: 34 nM
Beside the measured number, compound 4's estimate is 2.1-fold (0.31 log units) above it; measured number inside the range.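

In this assay, putting (pyridin-2-yl)methyl in place of pyridin-2-yl on the carbonyl carbon gave a 3.8-fold lower number from compound 2 to compound 4 (0.58 log units; beyond the scatter). This step lies beyond the usual scatter and the matching step on the core of compound 1 does not, yet the two steps cannot be told apart from each other: the same change on two cores in this assay, a 1.9-fold lower number (0.27 log units; within the scatter) from compound 1 to compound 3 and a 3.8-fold lower number (0.58 log units; beyond the scatter) from compound 2 to compound 4, 2.0-fold (0.31 log units) apart, within the scatter of two such steps. The change can therefore be read as carrying over from one core to the other with a similar effect, but two pairs do not show that one core responds differently from the other, that the change would carry over to any further core, or why it has this effect.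

The compounds shown leave open whether a longer chain on the carbonyl carbon, such as (pyridin-2-yl)ethyl, would continue the trend. They also leave open whether the pyridine nitrogen matters, which a (phenyl)methyl group at the same place would test.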